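A few compounds are considered here, and "the series" means these few. Any claim that something is new, unique, unknown or untested is made for them only; others in the source may bear on it.

Measured compounds in a functional assay on A549 cells (Homo sapiens) for cytotoxicity, read by MTT assay, with a stated time of 72 h; on this read-out higher numbers stand for weaker inhibition and lower numbers for stronger inhibition:

compound 1 `Cc1c(C(=O)Nc2ccc(Oc3ccnc4[nH]ccc34)c(F)c2)nnn1-c1ccccc1`, 360 nM
compound 2 `Cc1c(C(=O)Nc2ccc(Oc3ccnc4[nH]ccc34)c(F)c2)nnn1-c1ccc(F)c(F)c1`, 570 nM
compound 3 `Cc1c(C(=O)Nc2ccc(Oc3ccnc4[nH]ccc34)cc2)nnn1-c1ccccc1`, 420 nM

Compound 3 stands second highest of the three numbers, but all three lie within the scatter of one another, so no order among them can be read. The step from compound 1 to compound 3, hydrogen in place of fluoro on an aromatic carbon, gave a 1.2-fold higher number from compound 1 to compound 3 (0.07 log units; within the scatter).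

Compound 4 `Cc1c(C(=O)Nc2ccc(Oc3ccnc4[nH]ccc34)cc2)nnn1-c1ccc(Cl)c(C(F)(F)F)c1` differs from compound 3 in one place: 4-chloro-3-(trifluoromethyl)phenyl in place of phenyl on an aromatic nitrogen. Within the data shown here, the only measured step at the same position is the one from compound 1 to compound 2, a 3,4-difluorophenyl in place of phenyl on the aromatic nitrogen, which gave a 1.6-fold higher number from compound 1 to compound 2 (0.20 log units; within the scatter). Among the measured compounds shown here, that substituted phenyl is smaller than the 4-chloro-3-(trifluoromethyl)phenyl entering here, and no measured compound carries chloro or trifluoromethyl at this position, so the comparison is only partial. On what is shown, a small step, if any, toward a higher number is expected in this assay, as a 1.3-fold higher number from compound 3 to compound 4 (0.12 log units; within the scatter). Compound 4 is therefore estimated at 550 nM, with a range from 200 nM to 1500 nM.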

Compound 4, half-maximal inhibitory concentration: 2830 nM
Compound 4: middle estimate off by 5.1-fold (0.71 log units), on the low side; measured number outside the range, above it.
By their numbers in this assay, from the lowest: compounds 1, 3 and 2 (each within the scatter of the next); then compound 4.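

In this assay, among these compounds, the group on the aromatic nitrogen is not a silent position: 4-chloro-3-(trifluoromethyl)phenyl in place of phenyl gave a 6.7-fold higher number from compound 3 to compound 4 (0.83 log units; beyond the scatter), the only step beyond the scatter. The step to 3,4-difluorophenyl, taken on the fluoro-bearing parent, gave a 1.6-fold higher number from compound 1 to compound 2 (0.20 log units; within the scatter), so not every substitution of this phenyl moves the number measurably in the compounds shown. No available measurement bears on why the number rose here.

As far as these compounds go, it remains open whether the chloro or the trifluoromethyl carries the step, since the two enter together. Also open, from the compounds shown here alone, is how this phenyl would behave with an amine or a carboxylic acid in their place, and whether the step would hold with the fluoro of compound 1 on the shared core.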